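Swapping a Side Group for Benzoyl on a Second Core

The compounds below may be only part of what the source reports. "The series", "measured", "known", "first", "only" and "open" are said of these compounds alone.

Three compounds have been measured so far:
Compound 1 `O/N=C(/CSc1nnc(-c2ccccc2)n1-c1ccccc1)c1ccccc1` gives 65%.
Compound 2 `O=C(CSc1nnc(-c2ccccc2)n1-c1ccccc1)c1ccccc1` gives 64%.
Compound 3 `CCn1c(SC/C(=N/O)c2ccccc2)nnc1-c1ccc(OC)c(OC)c1` gives 71%.

All three numbers come from a functional assay on the whole organism (strain albino) for inhibition, with Rattus norvegicus as the target, read by paw edema, with a stated time of 3 h, at a dose of 0.28 mmol/kg by the oral route; on this read-out higher numbers stand for more inhibition at the one dose given (going by the name of the read-out) and lower numbers for less inhibition. Compound 1 and compound 2 share one core and differ in a single place: a group of 8 heavy atoms (7 carbon, 1 oxygen; one six-membered aromatic ring of carbon only) in place of a group of 9 heavy atoms (7 carbon, 1 nitrogen, 1 oxygen; one six-membered aromatic ring of carbon only), on a saturated chain carbon bound to a sulfur. That change made a step of a number 1 percentage points lower from compound 1 to compound 2 (within the scatter). Compound 3 is built on another core; the difference between the two cores is not broken down here. Its number sits close to those of compound 1 and compound 2, and all three lie within the usual scatter of one another, so no order among them can be read.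

Compound 4 `CCn1c(SCC(=O)c2ccccc2)nnc1-c1ccc(OC)c(OC)c1` has not yet been measured. It stands to compound 3 as compound 2 stands to compound 1: a group of 8 heavy atoms (7 carbon, 1 oxygen; one six-membered aromatic ring of carbon only) in place of a group of 9 heavy atoms (7 carbon, 1 nitrogen, 1 oxygen; one six-membered aromatic ring of carbon only), on a saturated chain carbon bound to a sulfur. The place of the change is the same in both pairs, so this is the same change carried out on the core of compound 3. Within the data shown here, the only guide to its effect is the earlier step, a number 1 percentage points lower from compound 1 to compound 2 (within the scatter), which hardly moved the read-out. For compound 4 the expected step is therefore a number 1 percentage points lower from compound 3 to compound 4 (within the scatter). This rests on one pair alone, and whether the change behaves alike on a second core cannot be checked from these compounds. The value of compound 4 in this assay is estimated at 70%, with a likely range from 58% to 82%.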

Compound 4, a percentage reported as inhibition, in the whole organism at one dose (the size of the read-out at that dose, not a potency): 61%
Beside the measured number, compound 4's estimate is 9 percentage points above it; the range from low to high includes it.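

On the core of compound 3, putting benzoyl in place of the group that leaves, on a saturated chain carbon bound to a sulfur, gives in this assay a step described as a number 10 percentage points lower from compound 3 to compound 4 (within the scatter). Set beside the same change on the core of compound 1, this step cannot be told apart from the earlier one: the same change on two cores in this assay, a number 1 percentage points lower (within the scatter) from compound 1 to compound 2 and a number 10 percentage points lower (within the scatter) from compound 3 to compound 4, 9 percentage points apart, within the scatter of two such steps. The two pairs therefore fit the idea that this change carries from one core to the other without a clear effect on the read-out, but they do not prove that it does, and they do not show that the larger of the two steps reflects a real difference between the cores.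

The compounds shown hold only these two groups at this place, so it stays open how an amine, a carboxylic acid or a longer chain on the same saturated carbon would read in this series. All the numbers also come from a single dose and a single time in one whole-animal test, so they leave open whether the compounds would still read alike at other doses or at other times.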